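This account rests on a few compounds, and the source may have more. Where it says the series, first, only, none or still open, it means among the compounds named here.

Compound 1, `CC(C)CCn1nc(-c2cccs2)c(O)c(C2=NS(=O)(=O)c3cc(OC(C)C(N)=O)ccc3N2)c1=O`, in an in vitro ADME assay on microsomes from liver (Homo sapiens) for metabolic stability, tested at 5 uM (a higher number here means that the compound lasts longer, a lower number that the compound disappears faster), gives 0.217 h.
Compound 2, `CC(C)CCn1nc(-c2cccs2)c(O)c(C2=NS(=O)(=O)c3cc(NC(=O)C4CC4)ccc3N2)c1=O`, in this assay gives 0.0833 h.

Within the data shown here, of these two numbers, compound 2 stands lowest: its single neighbour is compound 1, and the step of a 2.6-fold lower number from compound 1 to compound 2 (0.42 log units; beyond the scatter) lies beyond the scatter.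

Compound 3 is `CC(=O)Nc1ccc2c(c1)S(=O)(=O)N=C(c1c(O)c(-c3cccs3)nn(CCC(C)C)c1=O)N2`. It is derived from compound 2 by one change: methyl in place of cyclopropyl on a carbonyl carbon. Among the measured compounds shown here, no measured step covers this kind of exchange. For the measured compounds named here, the only step known, a 2.6-fold lower number from compound 1 to compound 2 (0.42 log units; beyond the scatter), changed a different part of the molecule, swapping an oxygen-linked group for an amide-linked one, and so says little about shortening the group on the amide carbonyl carbon. With no guidance from the data, the expected step of a 1.2-fold higher number from compound 2 to compound 3 (0.08 log units; within the scatter) is taken to fall within the usual scatter, in no particular direction.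

On that basis, the estimated half-life for compound 3 in this assay is 0.1 h, with a range from 0.04 h to 0.25 h.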

Compound 3, half-life: 0.055 h
Compound 3: middle estimate off by 1.8-fold (0.26 log units), on the high side, within the range that was stated.
By their numbers in this assay, from the lowest: compounds 3 and 2 (each within the scatter of the next); then compound 1.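

In this assay, methyl in place of cyclopropyl on the carbonyl carbon gives a 1.5-fold lower number from compound 2 to compound 3 (0.18 log units; within the scatter), so in this one pair, removing the three-membered ring leaves a difference that cannot be told from the scatter. The larger difference remains at the aromatic carbon: acetamido in place of 1-carbamoylethoxy gives a 3.9-fold lower number from compound 1 to compound 3 (0.60 log units; beyond the scatter), which agrees with the earlier 2.6-fold lower number from compound 1 to compound 2 (0.42 log units; beyond the scatter), as both amide-linked compounds stand apart from compound 1 by more than the scatter. No measurement shown gives a reason for any of these steps.

The compounds shown leave open how a longer chain such as propyl, or a group carrying an amine such as aminomethyl, would behave on this carbonyl carbon. They also leave open whether a carboxylic acid in place of the carbamoyl part of 1-carbamoylethoxy, on the same aromatic carbon, would come close to the half-life of compound 1, 0.217 h.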